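Hydrogen in place of carboxy: expected cytotoxicity of compound 4

The source may hold more compounds than are shown below. What is called first, only, known or untested is meant among the compounds shown, and "the series" means these compounds.

Compound 1 `O=C(O)c1ccc(OCCCCCn2ccc(=O)[nH]c2=O)cc1` carries a carboxy group on the aromatic ring. In an ADME assay on HEL cells (Homo sapiens) for cytotoxicity, read by microscopy (on this read-out lower numbers stand for higher toxicity in this test and higher numbers for lower toxicity in this test), compound 1 gives only a limit, > 100000 nM, not a number. Where compound 1 stands is therefore fixed only by the limit of > 100000 nM in this assay, at which 1 of the 3 values shown sits. Compound 2 `O=c1ccn(CCCCCOc2ccc(Br)cc2)c(=O)[nH]1` gives 100000 nM in this assay. Compound 3 `O=c1ccn(CCCCCOc2ccc([N+](=O)[O-])cc2)c(=O)[nH]1` gives 20000 nM in this assay. Compound 4 `O=c1ccn(CCCCCOc2ccccc2)c(=O)[nH]1` differs from compound 1 by hydrogen in place of carboxy on an aromatic carbon.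

Within the data shown here, three measured steps bear on this exchange. From compound 1 to compound 2, bromo in place of carboxy, the result is a number no higher from compound 1 to compound 2 (the limit leaves the size open). From compound 1 to compound 3, nitro in place of carboxy, the result is an at least 5.0-fold lower number from compound 1 to compound 3 (0.69 log units; beyond the scatter). From compound 2 to compound 3 the result is a 5.0-fold lower number from compound 2 to compound 3 (0.70 log units; beyond the scatter). Only the nitro compound, compound 3, moves the number clearly downward; the bromo compound, compound 2, does not move it beyond the scatter relative to the limit of compound 1.

Hydrogen is a smaller change than either bromo or nitro. The step from compound 1 to compound 4 in this assay is therefore expected to be a number no higher from compound 1 to compound 4 (the limit leaves the size open), that is, no movement beyond the scatter, with a fair chance that compound 4 again reaches only the limit. Compound 4 is estimated at 100000 nM in this assay, with a range from 40000 nM to 200000 nM.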

Compound 4, minimum cytotoxic concentration: > 100000 nM
Compound 4 ended at the assay's limit; the forecaster's own chance of this, stated with the estimate: 45%; the middle value lies on the limit itself.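

In this assay compound 4 gives > 100000 nM, which is a limit of the assay and not a number. With hydrogen on the aromatic carbon para to a large group, the series shows an at least 5.0-fold higher number from compound 3 to compound 4 (0.69 log units; beyond the scatter), and also a number no lower from compound 2 to compound 4 (the limit leaves the size open), so among the four compounds only the nitro compound, compound 3, has a reading clearly set apart from the others at this position. Loss of the carboxy group alone therefore does not bring the number down to the level of compound 3, and the top of the range now holds both the carboxy and the hydrogen compound: the limit of > 100000 nM in this assay, at which 2 of the 4 values shown sit.

On these data alone, the step between compound 1 and compound 4 cannot be read, as both stand at the limit, so any difference between carboxy and hydrogen at this position stays hidden, and the size of the step from compound 2 stays open as well. As far as these compounds go, whether the lower number goes with nitro alone or would also appear with an amine, a methoxy group or a nitrile at the same place remains open, as does the effect of a longer chain on the core of compound 4.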